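The compounds below may be only part of what the source reports. "The series", "measured", "known", "first", "only" and "open" are said of these compounds alone.

Measured compounds and their values in a functional assay on CHO cells with sphingosine 1-phosphate receptor 2 (Homo sapiens) as the target, read by GTPgammaS binding; a higher number here means that more compound is needed for the effect, a lower number that less compound is needed:

Compound 1 `CC[C@H](C)Oc1ccc(-c2nc(-c3ccc(CCC(=O)O)cc3C)no2)cc1C#N`: > 10000 nM, a limit of the assay.
Compound 2 `Cc1cc(CCC(=O)O)ccc1-c1noc(-c2ccc(OC(C)C(F)(F)F)c(C#N)c2)n1`: > 10000 nM, a limit of the assay.
Compound 3 `Cc1cc(CCC(=O)O)ccc1-c1noc(-c2ccc(OC(C(F)(F)F)C(F)(F)F)c(C#N)c2)n1`: > 10000 nM, a limit of the assay.

Compound 3 therefore stands only at the limit, not at a number, and the same holds for the other two values shown; all three sit at the limit of > 10000 nM in this assay, at which 3 of the 3 values shown sit. The steps between the measured compounds are accordingly not readable: a step that the two limits leave unreadable from compound 1 to compound 2, a step that the two limits leave unreadable from compound 1 to compound 3 and a step that the two limits leave unreadable from compound 2 to compound 3 are all hidden by the two limits.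

Compound 4 `Cc1cc(CCC(=O)O)ccc1-c1noc(-c2ccc(OCC(F)(F)F)c(C#N)c2)n1` differs from compound 3 by hydrogen in place of trifluoromethyl on a saturated chain carbon bound to an oxygen on an aromatic ring and a saturated chain carbon. Among the measured compounds shown here, the change related most closely to it is the one from compound 2 to compound 3, where a trifluoromethyl replaced a methyl at the same place, and that step gave no readable size. Nothing in the measured set points away from the limit, so compound 4 is expected to remain there as well, with an expected step that the limit leaves unreadable from compound 3 to compound 4. The estimate for compound 4 in this assay is 12000 nM, with a range from 4000 nM to 40000 nM, and most likely the assay reports only a limit again.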

Compound 4, half-maximal effective concentration: > 10000 nM
Compound 4: no number, only a limit; the forecaster's own chance of this, stated with the estimate: 85%; the middle value is on the limit's open side.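

In this assay compound 4 gives > 10000 nM, a limit of the assay. Its steps from compound 1, compound 2 and compound 3 therefore cannot be read: the limit of > 10000 nM in this assay, at which 4 of the 4 values shown sit.

The compounds shown leave open how far each lies past that limit, and whether changing the group on the oxygen alters the response at all.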